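This account rests on a few compounds, and the source may have more. Where it says the series, first, only, none or still open, it means among the compounds named here.

Going by the values given here, in a functional assay on NCI-H23 cells (Homo sapiens) for inhibition, read by sulforhodamine B assay, with a stated time of 48 h, tested at 100 uM (a lower number here means a stronger effect, a higher number a weaker effect of the compound at the concentration tested), compound 2 `COc1cc(Cl)cc(-c2nn(-c3cccc(NC(=O)Nc4cccc(C(F)(F)F)c4)c3)cc2-c2ccncc2)c1` gives -40%, the higher of the two numbers measured so far; its nearest neighbour, compound 1 `COc1cc(Cl)cc(-c2nn(-c3cccc(NC(=O)Nc4ccc(Cl)c(C(F)(F)F)c4)c3)cc2-c2ccncc2)c1`, gives -50% in this assay, and the step of a number 10 percentage points higher from compound 1 to compound 2 (within the scatter) lies within the scatter. Compound 3 `COc1cc(Cl)cc(-c2nn(-c3cccc(NC(=O)c4cccc(C(F)(F)F)c4)c3)cc2-c2ccncc2)c1` has not yet been measured. It differs from compound 2 by 3-(trifluoromethyl)phenyl in place of (3-(trifluoromethyl)phenyl)amino on a carbonyl carbon. Among the compounds with values here, no measured step touches the amide-type nitrogen or the carbonyl carbon, so the only known change, hydrogen in place of chloro on an aromatic carbon, does not bear on this one, and it was in any case within the scatter. Within the data shown here, with no comparable step to lean on, compound 3 is expected to stay close to compound 2, with a step of a number 10 percentage points higher from compound 2 to compound 3 (within the scatter) that is estimated to remain within the scatter, although the range must be set wide. The expected value for compound 3 in this assay is -30%, estimated to fall between -65% and 10%.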

Compound 3, a percentage reported as activity, at one concentration (the size of the read-out at that concentration, not a potency): 27%
Compound 3: middle estimate off by 57 percentage points, on the low side; the whole stated range lies below it.
By their numbers in this assay, from the lowest: compounds 1 and 2 (each within the scatter of the next); then compound 3.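

In this assay the carbonyl carbon proves to be a sensitive place, which the chloro change did not show: 3-(trifluoromethyl)phenyl in place of (3-(trifluoromethyl)phenyl)amino gives a number 67 percentage points higher from compound 2 to compound 3 (beyond the scatter) in this read-out. The exchange starting from the chloro-bearing group gives a number 77 percentage points higher from compound 1 to compound 3 (beyond the scatter) and so points the same way, with both amino-linked compounds standing well below compound 3. The data at hand offer no explanation for this loss of effect.

From the compounds shown here alone, it remains open whether the amide-type nitrogen of the amino link can be replaced by an oxygen atom or a methylene group, or carry a methyl group, and keep the stronger effect. Going by these compounds, it is also open whether 4-chloro-3-(trifluoromethyl)phenyl placed directly on the carbonyl carbon would behave like compound 3.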